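From compound 3 to compound 4: a changed amine chain

The source may hold more compounds than are shown below. What is called first, only, known or untested is meant among the compounds shown, and "the series" means these compounds.

- Compound 1 `CCOc1c(-c2cc(OC)c(OC)c(OC)c2)oc2ccccc2c1=O`: 5400 nM
- Compound 2 `COc1cc(-c2oc3ccccc3c(=O)c2OC(C)C)cc(OC)c1OC`: 8800 nM
- Compound 3 `CCN(CC)CCCCCOc1c(-c2cc(OC)c(OC)c(OC)c2)oc2ccccc2c1=O`: 10000 nM

All three values come from a functional assay on LNCaP cells (Homo sapiens) for antiproliferative activity, read by WST assay, with a stated time of 3 days; on this read-out lower numbers stand for stronger inhibition and higher numbers for weaker inhibition. Compound 3, at 10000 nM, cannot be told apart from the other two compounds: the data show a 1.9-fold higher number from compound 1 to compound 3 (0.27 log units; within the scatter) and a 1.1-fold higher number from compound 2 to compound 3 (0.06 log units; within the scatter). Compound 1 and compound 2 also lie within the scatter of each other, with a 1.6-fold higher number from compound 1 to compound 2 (0.21 log units; within the scatter).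

Compound 4 `CCCCCN(CCCCC)CCCCOc1c(-c2cc(OC)c(OC)c(OC)c2)oc2ccccc2c1=O` has not yet been measured. The structural change that leads to it is dipentylamino in place of (diethylamino)methyl on a saturated chain carbon, four bonds along the chain from an oxygen on an aromatic ring. Among the measured compounds shown here, no measured step swaps one amine group for another on a chain, so the data hold no direct precedent. The closest evidence is indirect. Exchanging isopropyl for 5-(diethylamino)pentyl gave a 1.1-fold higher number from compound 2 to compound 3 (0.06 log units; within the scatter), and adding 3-(diethylamino)propyl gave a 1.9-fold higher number from compound 1 to compound 3 (0.27 log units; within the scatter). Both steps stayed within the scatter, although each one added a sizeable chain.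

In this assay the expected step is therefore none beyond the scatter, an estimated 1.4-fold lower number from compound 3 to compound 4 (0.15 log units; within the scatter). With such thin precedent, the range is kept wide. For compound 4 the estimate is 7000 nM, expected to fall between 2500 nM and 15000 nM.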

Compound 4, half-maximal inhibitory concentration: 9700 nM
Estimate against measurement, compound 4: 1.4-fold (0.14 log units) below, within the range that was stated.
By their numbers in this assay, from the lowest: compounds 1, 2, 4 and 3 (each within the scatter of the next).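

In this assay, the swap of (diethylamino)methyl for dipentylamino on a saturated chain carbon, four bonds along the chain from an oxygen on an aromatic ring, gives a 1.0-fold lower number from compound 3 to compound 4 (0.01 log units; within the scatter). This is the first direct exchange of one amine group for another in the compounds shown, and it cannot be told apart from no change at all, even though the entering group has 11 heavy atoms against 6 for the group that leaves, so at this position and in this read-out the two open-chain amine ends are not distinguished. No measurement is available that would explain this result.

Going by these compounds, both amine ends here are open-chain groups with no ring, so it remains open whether a ring amine such as piperidine or morpholine at the end of the chain, or a carboxylic acid in place of the amine, would move the number beyond the scatter. A shorter or longer chain between the oxygen and the nitrogen is also untested in the compounds shown, as is a primary amine carrying no alkyl groups.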